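Putting a Side Chain Back on Compound 3

This account rests on a few compounds, and the source may have more. Where it says the series, first, only, none or still open, it means among the compounds named here.

In a functional assay on NCI-H1581 cells (Homo sapiens) for antiproliferative activity, read by CCK-8 assay, with a stated time of 72 h (on this read-out lower numbers stand for stronger inhibition and higher numbers for weaker inhibition), compound 3 `COc1cc(OC)c(Cl)c(-c2ccc3c(NC(=O)c4ccccc4)n[nH]c3n2)c1Cl` is reported only as a limit (> 1000 nM), not as a number. Compound 1 `COc1cc(OC)c(Cl)c(-c2ccc3c(NC(=O)c4ccc(N5CCN(C)CC5)cc4)n[nH]c3n2)c1Cl` gives 1.7 nM and compound 2 `COc1cc(OC)c(Cl)c(-c2ccc3c(NC(=O)c4ccc(C5CCN(C)CC5)cc4)n[nH]c3n2)c1Cl` gives 8.2 nM. Compound 4 `COc1cc(OC)c(Cl)c(-c2ccc3c(NC(=O)c4ccc(N(C)CCN(C)C)cc4)n[nH]c3n2)c1Cl` carries (2-(dimethylamino)ethyl)(methyl)amino in place of hydrogen on an aromatic carbon. Two measured steps run the opposite way, replacing a group there with hydrogen (an at least 580-fold higher number from compound 1 to compound 3 (2.76 log units; beyond the scatter)) and (an at least 120-fold higher number from compound 2 to compound 3 (2.08 log units; beyond the scatter)), and both are large. Exchanging one ring-bearing group for another was modest (a 4.8-fold higher number from compound 1 to compound 2 (0.68 log units; beyond the scatter)). From the compounds shown here alone, the new chain has no ring and remains untested here, yet a large step toward stronger inhibition is expected (an at least 66-fold lower number from compound 3 to compound 4 (1.82 log units; beyond the scatter)). Compound 4 is estimated at 15 nM (expected range 3 nM to 100 nM).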

Compound 4, half-maximal inhibitory concentration: 11 nM
For compound 4 the middle estimate is 1.4-fold (0.13 log units) above the measured one, within the range that was stated.
By their numbers in this assay, from the lowest: compound 1; then compounds 2 and 4 (each within the scatter of the next). At a limit, above all of these: compound 3.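

An open chain with no ring works at this position on the six-membered aromatic ring, giving an at least 90-fold lower number from compound 3 to compound 4 (1.95 log units; beyond the scatter), so a ring in the side chain is not required for strong inhibition here. That step starts from a limit, not a number: the limit of > 1000 nM in this assay, at which 1 of the 4 values shown sits. The new chain matches the 1-methylpiperidin-4-yl group, with a 1.3-fold higher number from compound 2 to compound 4 (0.13 log units; within the scatter), but falls short of the 4-methylpiperazin-1-yl group, with a 6.5-fold higher number from compound 1 to compound 4 (0.81 log units; beyond the scatter).

All three side chains shown contain an amine. A methoxy group or a morpholine in the same place would show how much depends on that amine and how much on the chain's bulk alone.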